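The compounds below may be only part of what the source reports. "The series", "measured", "known", "first", "only" and "open" are said of these compounds alone.

Measured compounds:

Compound 1, `C[C@H](NC(=O)c1nnn(Cc2ccc(C(F)(F)F)cc2)c1C(F)(F)F)c1ccc(C(=O)O)cc1` — in a functional assay on CHO cells for antagonist activity at prostaglandin E2 receptor EP4 subtype (Homo sapiens), read by calcium flux, with a stated time of 15 min (on this read-out higher numbers stand for weaker inhibition and lower numbers for stronger inhibition), compound 1 gives a value that is only a limit of the assay, > 10000 nM.

Compound 2, `C[C@H](NC(=O)c1c(-c2ccccc2)nnn1Cc1ccccc1)c1ccc(C(=O)O)cc1` — in this assay compound 2 gives 647 nM.

For the measured compounds named here, compound 2 stands alone as the single numerical result in this assay; the other value shown is a limit, so no measured step between two numbers exists here, and the limit of > 10000 nM in this assay, at which 1 of the 2 values shown sits, describes where that limit sits. Compound 3, `COc1cccc(Cn2nnc(-c3ccccc3)c2C(=O)N[C@@H](C)c2ccc(C(=O)O)cc2)c1`, is not yet measured. It differs from compound 2 in one place: methoxy in place of hydrogen on an aromatic carbon, cut one bond further out a benzyl becoming a 3-methoxybenzyl. With no measured step of this kind among the compounds shown, the account expects the change to leave the inhibitory concentration close to that of compound 2, with any movement in this assay not clearly beyond the usual scatter in either direction. For compound 3 the estimated result is 500 nM, expected to fall between 150 nM and 1600 nM, which means an expected step of a 1.3-fold lower number from compound 2 to compound 3 (0.11 log units; within the scatter).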

Compound 3, half-maximal inhibitory concentration: 96.8 nM
Estimate against measurement, compound 3: 5.2-fold (0.71 log units) above; measured number below the stated range.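

In this assay, for the compounds shown here, methoxy in place of hydrogen on an aromatic carbon of the benzyl gives a 6.7-fold lower number from compound 2 to compound 3 (0.83 log units; beyond the scatter) and supplies the first step between two measured numbers. Going by these compounds alone, it shows that this carbon, meta to a large group, is not a silent place: the benzyl ring carries the added methoxy with no loss of inhibition, and the number moves toward stronger inhibition, which the single value for the plain benzyl could not reveal. Nothing shown accounts for the size or the direction of this step, so it stands as an observation only.

Going by these compounds, whether this gain belongs to the methoxy itself, or would also come with a chlorine, a hydroxyl or an ethoxy on the same carbon, stays open. Also open, on these data alone, is whether a methoxy would act in the same way on another carbon of the benzyl ring or on the phenyl group of the core, for one step at one position says nothing about any other.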